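Shortening the Ester Chain at the Adenosine Receptor

The source may report more compounds than this note shows. Statements on the series, on what has been measured and on what is new or still open speak of the compounds shown alone.

Of the compounds shown here, three have been measured in an assay on HEK293 cells for displacement of a labelled ligand from adenosine receptor A2b (Homo sapiens), read by radioligand binding, with a stated time of 30 min, tested at 1 uM; a lower number here means less inhibition, a higher number more inhibition at the concentration tested (going by the name of the read-out). Compound 1 `CC1=C(C(=O)OCC(F)(F)F)C(c2ccsc2)NC(=O)N1` gives 24%, compound 2 `CC1=C(C(=O)OC(C)C(F)(F)F)C(c2ccsc2)NC(=O)N1` gives 1%, and compound 3 `CC(C)OC(=O)C1=C(C(F)(F)F)NC(=O)NC1c1cccs1` gives 19%. Compound 2 and compound 1 differ by hydrogen in place of methyl on a saturated chain carbon bound to an oxygen next to a carbonyl group and a saturated chain carbon, and that change gave a number 23 percentage points higher from compound 2 to compound 1 (beyond the scatter). Compound 4 `CCOC(=O)C1=C(C(F)(F)F)NC(=O)NC1c1cccs1` has not been measured; it differs from compound 3 by hydrogen in place of methyl on a saturated chain carbon bound to an oxygen next to a carbonyl group and a saturated chain carbon, the same change at the same place. The cores of compound 3 and compound 2 are built from the same atoms joined differently, and that difference is not broken down here. Because the earlier step gave a number 23 percentage points higher from compound 2 to compound 1 (beyond the scatter), a rise of the same kind is expected here, estimated as a number 13 percentage points higher from compound 3 to compound 4 (beyond the scatter), though a single prior example makes the expectation loose. Compound 4 is expected to give 32%, between 12% and 52%.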

Compound 4, a percentage reported as inhibition, at one concentration (the size of the read-out at that concentration, not a potency): 16%
Beside the measured number, compound 4's estimate is 16 percentage points above it; the range from low to high includes it.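

In this assay, hydrogen in place of methyl gave a number 3 percentage points lower from compound 3 to compound 4 (within the scatter), so the change did not behave alike on the two cores: the same change on two cores in this assay, a number 23 percentage points higher (beyond the scatter) from compound 2 to compound 1 and a number 3 percentage points lower (within the scatter) from compound 3 to compound 4, 26 percentage points apart, beyond the scatter of two such steps

The step seen on the core of compound 1 therefore cannot simply be carried over to the core of compound 3 in this series. Two pairs do not show which difference between the cores separates the steps, nor how the change would behave on any further core.

The compounds shown leave open how a longer chain at the ester would behave on either core. They also leave open what a carboxylic acid or an amide in place of the ester would do.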